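Acetamide-capped chains: truncating compound 3 to compound 4

The source may hold more compounds than are shown below. What is called first, only, known or untested is meant among the compounds shown, and "the series" means these compounds.

Compound 1 `CC(=O)NCCNC(=O)CCNC(C)=O` sits at the assay limit in a functional assay on HL-60 cells (Homo sapiens) for cytotoxicity (on this read-out higher numbers stand for weaker inhibition and lower numbers for stronger inhibition), giving > 16000000 nM. Compound 2 `CC(=O)NCCC(=O)NCCNC(=O)CCNC(C)=O` gives a number in this assay, 6000000 nM. For the measured compounds named here, the one step with numbers at both ends, an at least 2.6-fold lower number from compound 1 to compound 2 (0.42 log units; beyond the scatter), adds an acetamidomethyl group and lowers the number. Compound 3 `CC(=O)NCCCN(CCCCN(CCCNC(C)=O)C(C)=O)C(C)=O` also reaches only the assay limit in this assay, > 16000000 nM. Compound 3 therefore stands at the limit of > 16000000 nM in this assay, at which 2 of the 3 values shown sit, with no number to rank it against compound 2.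

Compound 4 `CC(=O)NCCCCN(CCCNC(C)=O)C(C)=O` differs from compound 3 by hydrogen in place of 3-acetamidopropyl on an amide-type nitrogen. Going by the values given here, the only step measured so far runs the other way, adding a chain, and its size from compound 1 to compound 2 was at least modest. Taking a 3-acetamidopropyl group off compound 3 is not expected to lower the number in this assay; the more likely outcome is that compound 4 again returns only a limit. Compound 4 is estimated at 16000000 nM, with a range from 5000000 nM to 50000000 nM. The expected step is a number no higher from compound 3 to compound 4 (the limit leaves the size open), effectively none beyond the scatter.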

Compound 4, half-maximal inhibitory concentration: > 16000000 nM
Compound 4 ended at the assay's limit (the forecaster's own chance of this, stated with the estimate: 70%); the middle value sits exactly at the limit.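

Compound 3 and compound 4 both return only a limit in this assay, so no step between them can be read: the limit of > 16000000 nM in this assay, at which 3 of the 4 values shown sit.

Left open is the size, and even the direction, of any change from putting hydrogen in place of 3-acetamidopropyl on the amide-type nitrogen.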